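Lengthening the Side Chain of a Carbamate Pyridone

The compounds below may be only part of what the source reports. "The series", "measured", "known", "first", "only" and "open" are said of these compounds alone.

Compound 1 `CC(C)=CCC1Cc2c(OC(=O)Nc3ccc(Cl)cc3)cc(=O)n(CCCO)c2CC1(C)C` and compound 2 `CC(C)=CCC1Cc2c(OC(=O)Nc3ccc(Cl)c(Cl)c3)cc(=O)n(CCCO)c2CC1(C)C` share one core and differ only in the aryl ring of the carbamate. In a functional assay on PANC-1 cells (Homo sapiens) for inhibition, read by MTT assay, with a stated time of 24 h, tested at 10 uM (a higher number here means more inhibition at the concentration tested (going by the name of the read-out), a lower number less inhibition), compound 1 gives 49.8%, and compound 2 gives 61.4%. Among the compounds with values here, of the two numbers so far, compound 1 stands lowest; the step of a number 11.6 percentage points higher from compound 1 to compound 2 (beyond the scatter) came from chloro in place of hydrogen on an aromatic carbon. Compound 3 `CC(C)=CCC/C(C)=C/CC1Cc2c(OC(=O)Nc3ccc(Cl)cc3)cc(=O)n(CCCO)c2CC1(C)C` has not yet been measured. It differs from compound 1 in another part of the molecule: 3-methylbut-2-en-1-yl in place of hydrogen on a saturated chain carbon bound to a double-bonded chain carbon. Within the data shown here, no measured step touches this part of the structure; the only step on record alters the aryl ring, is modest in size, and says nothing about lengthening the chain. With nothing pointing either way, compound 3 is expected to stay close to compound 1 in this assay. The step of a number 0.2 percentage points higher from compound 1 to compound 3 (within the scatter) is expected to fall within the scatter. Compound 3 is therefore estimated at 50%, with a range from 35% to 65%.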

Compound 3, a percentage reported as inhibition, at one concentration (the size of the read-out at that concentration, not a potency): 47.2%
Compound 3: middle estimate off by 2.8 percentage points, on the high side; the measured number falls inside the stated range.
By their numbers in this assay, from the lowest: compounds 3 and 1 (each within the scatter of the next); then compound 2.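

Swapping the 3-methylbut-2-en-1-yl chain of compound 1 for the 3,7-dimethylocta-2,6-dien-1-yl chain of compound 3 adds 5 heavy atoms, all carbon, and in this assay gives a number 2.6 percentage points lower from compound 1 to compound 3 (within the scatter). This chain can therefore be lengthened without a difference that this read-out can separate from ordinary scatter, at least for this one extension at the single concentration tested. The aryl ring of the carbamate remains the only part of the molecule shown to shift the number, with a number 11.6 percentage points higher from compound 1 to compound 2 (beyond the scatter), while the chain has shown no such shift; no measurement at hand offers an explanation for either result.

The compounds shown leave open whether the added chloro of compound 2 would have the same effect on a molecule carrying the longer chain of compound 3. They also leave open how the number would respond if this chain ended in an amine or a carboxylic acid rather than in plain carbon, or if it were longer still.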